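The compounds below may be only part of what the source reports. "The series", "measured", "known", "first", "only" and "open" are said of these compounds alone.

Measured so far in a physicochemical assay for solubility, read by spectrophotometry, in phosphate buffer, with a stated time of 2 h, at pH 7.4; a lower number here means a less soluble compound, a higher number a more soluble compound:

Compound 1 `COc1ccc2[nH]c(C(=O)N3CC(=O)N(Cc4ccccc4)[C@@H](CN4CCN(S(=O)(=O)c5ccccc5)CC4)C3)cc2c1`, compound 1 gives 16900 nM.
Compound 2 `COc1ccc2[nH]c(C(=O)N3CC(=O)N(Cc4ccccc4)[C@@H](CN4CCN(c5ccccn5)CC4)C3)cc2c1`, compound 2 gives 30200 nM.

Compound 2 holds the highest of the two numbers, but its nearest neighbour is compound 1, and the step of a 1.8-fold higher number from compound 1 to compound 2 (0.25 log units; within the scatter) lies within the scatter, so no order between the two is claimed.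

The next compound is compound 3 `COc1ccc2[nH]c(C(=O)N3CC(=O)N(Cc4ccccc4)[C@@H](CN4CCN(Cc5ccccn5)CC4)C3)cc2c1`. It differs from compound 2 in one place: (pyridin-2-yl)methyl in place of pyridin-2-yl on an amine nitrogen in a ring.

For the measured compounds named here, only one measured step touches this position, the exchange of the group on the same ring nitrogen, a 1.8-fold higher number from compound 1 to compound 2 (0.25 log units; within the scatter), and it did not move the number beyond the scatter. Going by the values given here, no measured step inserts a single carbon between that nitrogen and an aromatic ring, so the present change is not directly covered. The expectation for this assay is therefore a small step, a 1.4-fold higher number from compound 2 to compound 3 (0.14 log units; within the scatter), leaning upward but not confidently beyond the scatter. Compound 3 is estimated at 42000 nM, with a range from 15000 nM to 120000 nM.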

Compound 3, solubility: > 100000 nM
Compound 3 gave a limit, no number; the forecaster's own chance of this, stated with the estimate: 5%; middle value at least 2.3-fold (0.37 log units) from the limit.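

In this assay this position can move the read-out beyond the scatter, which the earlier exchange on this amine nitrogen in a ring did not do: (pyridin-2-yl)methyl in place of pyridin-2-yl gives an at least 3.3-fold higher number from compound 2 to compound 3 (0.51 log units; beyond the scatter) in this series. Against phenylsulfonyl on the same nitrogen, the same group gives an at least 5.9-fold higher number from compound 1 to compound 3 (0.77 log units; beyond the scatter) and this step also lies beyond the scatter. For compound 3 the value > 100000 nM is a limit of the assay and not a number: the limit of > 100000 nM in this assay, at which 1 of the 3 values shown sits.

From the compounds shown here alone, the size of both steps stays open past that limit. Also open, going by these compounds, is whether the rise follows the added carbon or needs the aromatic nitrogen of the (pyridin-2-yl)methyl group, and a benzyl group or a longer chain such as 2-(pyridin-2-yl)ethyl on the same nitrogen would separate the two.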